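Ester to secondary amide on the methoxylated chain

A few compounds are considered here, and "the series" means these few. Any claim that something is new, unique, unknown or untested is made for them only; others in the source may bear on it.

Of the compounds shown here, three of the shared core have been measured in a physicochemical assay for lipophilicity; on this read-out lower numbers stand for lower lipophilicity and higher numbers for higher lipophilicity. Compound 1 `CCCOC(=O)/C=C(C)/C=C/CC(C)CCCC(C)C` gives 7.28, compound 2 `CCCOC(=O)/C=C(C)/C=C/CC(C)CCCC(C)(C)OC` gives 6.08, and compound 3 `CCN(CC)C(=O)/C=C(C)/C=C/CC(C)CCCC(C)C` gives 6.02. Compound 2 stands well below compound 1, with a number 1.20 log units lower from compound 1 to compound 2 (beyond the scatter), while compound 2 and compound 3 cannot be told apart within the scatter.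

Compound 4 `CCNC(=O)/C=C(C)/C=C/CC(C)CCCC(C)(C)OC` is not yet measured. Against compound 2 it shows (ethylamino in place of propoxy on a carbonyl carbon). For the measured compounds named here, the one step that bears on it is the exchange at the carbonyl carbon of compound 1 into compound 3, a number 1.26 log units lower from compound 1 to compound 3 (beyond the scatter), where diethylamino took the place of propoxy; there the number dropped clearly beyond the scatter. Ethylamino in place of propoxy touches the same carbonyl carbon, and the methoxy on the chain is held constant between compound 2 and compound 4, so a drop of similar size is the plain expectation in this assay. Compound 4 is therefore expected to come out at about 4.7, with a range from 4.1 to 5.3, the estimated step being a number 1.38 log units lower from compound 2 to compound 4 (beyond the scatter) because the earlier exchange gave a number 1.26 log units lower from compound 1 to compound 3 (beyond the scatter).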

Compound 4, partition coefficient: 4.04
For compound 4 the middle estimate is 0.66 log units above the measured one; measured number below the stated range.
By their numbers in this assay, from the lowest: compound 4; then compounds 3 and 2 (each within the scatter of the next); then compound 1.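

In this assay, ethylamino in place of propoxy on a carbonyl carbon gives a number 2.04 log units lower from compound 2 to compound 4 (beyond the scatter), so an exchange at this carbon also lowers the number on the chain that carries methoxy, not only on the chain of compound 1. This step reads larger than a number 1.26 log units lower from compound 1 to compound 3 (beyond the scatter), but the two steps differ both in the entering group and in the chain, so the difference in size cannot be assigned to either one. Ethylamino enters with 1 hydrogen-bond donor where propoxy has 0, but no measurement here ties the step to that count or to any other explanation.

Still open, on these data alone, is whether diethylamino on the chain of compound 2, or ethylamino on the chain of compound 1, would show a step closer to a number 1.26 log units lower from compound 1 to compound 3 (beyond the scatter) or to a number 2.04 log units lower from compound 2 to compound 4 (beyond the scatter), a comparison that would separate the entering group from the chain. Also open, as far as these compounds go, is how a methylamino, propylamino or plain amino group on the same carbonyl carbon would read in this assay, and whether a longer chain in place of methoxy would keep the size of the step.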